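The source may report more compounds than this note shows. Statements on the series, on what has been measured and on what is new or still open speak of the compounds shown alone.

Compound 3, whose structure is `CC#CCn1c(N2CCC[C@@H](N)C2)nc2c1c(=O)n(Cc1cc(C#N)ccc1C(=O)O)c(=O)n2C`, is the starting point here. In an ADME assay on isolated protein for inhibition of Dipeptidyl peptidase 9 (Homo sapiens), with stated times of 15 min, 60 s and 20 min (a higher number here means a weaker inhibitor, a lower number a stronger inhibitor), compound 3 gives only a limit, > 100000 nM, so no number for its potency is known. Its neighbours share a common core. Compound 1, `CC#CCn1c(N2CCC[C@@H](N)C2)nc2c1c(=O)n(Cc1ccc(Br)cc1C(=O)OC)c(=O)n2C`, in this assay also reaches only a limit, > 100000 nM. Compound 2, `CC#CCn1c(N2CCC[C@@H](N)C2)nc2c1c(=O)n(Cc1ccccc1C(=O)O)c(=O)n2C`, likewise gives a limit in this assay, > 100000 nM. All three values sit at the same limit, as noted in the limit of > 100000 nM in this assay, at which 3 of the 3 values shown sit, so the steps among them cannot be read: a step that the two limits leave unreadable from compound 1 to compound 2, a step that the two limits leave unreadable from compound 1 to compound 3 and a step that the two limits leave unreadable from compound 2 to compound 3.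

Compound 4, `CC#CCn1c(N2CCC[C@@H](N)C2)nc2c1c(=O)n(Cc1ccc(Br)cc1C(=O)O)c(=O)n2C`, has not been measured. Its change from compound 3 is 4-bromo-2-carboxyphenyl in place of 2-carboxy-5-cyanophenyl on a saturated chain carbon bound to an aromatic nitrogen. The steps that touch the same part of the molecule are those from compound 1 to compound 2 and compound 3 and from compound 2 to compound 3, and each is unreadable because of the limit of > 100000 nM in this assay, at which 3 of the 3 values shown sit. With three limits and no readable step, the expectation is that compound 4 will again sit at the limit, and the expected step that the limit leaves unreadable from compound 3 to compound 4 is therefore none beyond the scatter. The estimate for compound 4 in this assay is 150000 nM, with a range from 60000 nM to 500000 nM, most likely reported only as a limit.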

Compound 4, half-maximal inhibitory concentration: > 100000 nM
Compound 4 was reported as a limit (the forecaster's own chance of this, stated with the estimate: 85%); the middle value does not contradict the limit.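

In this assay, within the data shown here, compound 4 gives > 100000 nM which is only a limit, so no step to compound 4 from compound 1, compound 2 or compound 3 can be read: the limit of > 100000 nM in this assay, at which 4 of the 4 values shown sit. The compounds shown leave open how strongly any of the four inhibits this enzyme, and whether swapping the groups on the phenyl ring changes that inhibition at all.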